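A Methoxy Added on an Aromatic Carbon

This account rests on a few compounds, and the source may have more. Where it says the series, first, only, none or still open, it means among the compounds named here.

Four related compounds were compared in a functional assay on NCI/ADR-RES cells (Homo sapiens) for inhibition, read by sulforhodamine B assay, with a stated time of 48 h; on this read-out higher numbers stand for weaker inhibition of growth and lower numbers for stronger inhibition of growth. Compound 1 `C=C(C)[C@@H]1CC=C(Cn2cc(COc3cccc(C4NC(=O)NC(C)=C4C(=O)OCC)c3)nn2)CC1` was tested in this assay, and for compound 1 the result is only a limit, > 100000 nM. Compound 2 `C=C(C)[C@@H]1CC=C(Cn2cc(COc3cc(C4NC(=O)NC(C)=C4C(=O)OCC)ccc3OC)nn2)CC1` differs from compound 1 by methoxy in place of hydrogen on an aromatic carbon. For compound 2 this assay likewise reports only a limit, > 100000 nM. The step that the two limits leave unreadable from compound 1 to compound 2 therefore has no readable size. Compound 3 `C=C(C)[C@@H]1CC=C(Cn2cc(COc3ccc(C4NC(=O)NC(C)=C4C(C)=O)cc3)nn2)CC1` carries a different core; the difference between the two cores is not broken down here. For compound 3 this assay again gives only a limit, > 100000 nM. All three values thus sit at the limit of > 100000 nM in this assay, at which 3 of the 3 values shown sit.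

Compound 4 `C=C(C)[C@@H]1CC=C(Cn2cc(COc3ccc(C4NC(=O)NC(C)=C4C(C)=O)cc3OC)nn2)CC1` has not yet been measured. It differs from compound 3 by methoxy in place of hydrogen on an aromatic carbon. This is the same kind of change as that from compound 1 to compound 2, though the surroundings differ: in compound 2 the methoxy sits para to a large group, whereas in compound 4 it sits meta to a large group. Because compound 3 gives only the limit > 100000 nM, the step to compound 4 is hard to read. The earlier step that the two limits leave unreadable from compound 1 to compound 2 gave no readable size either. The step that the limit leaves unreadable from compound 3 to compound 4 is expected to be equally unreadable, with compound 4 remaining at the limit. Compound 4 is therefore estimated to give 150000 nM.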

Compound 4, concentration for total growth inhibition: 80200 nM
The estimate for compound 4 lay 1.9-fold (0.27 log units) above the measured number; measured number inside the range.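

In this assay, methoxy in place of hydrogen on an aromatic carbon gives an at least 1.2-fold lower number from compound 3 to compound 4 (0.09 log units; that floor lies within the scatter), so this step alone does not establish a real gain, although its true size could be larger. The same change on the core of compound 1 gives a step that cannot be read, so these results do not show whether the change carries from one core to the other, in either direction. The data leave little room for such a comparison: the limit of > 100000 nM in this assay, at which 3 of the 4 values shown sit.

Compound 4 gives 80200 nM. The compounds shown leave open whether an amine or a carboxylic acid in place of the methoxy, on the same aromatic carbon, would bring the number lower than in compound 4. They also leave open whether methoxy would give a readable step on any core where the compound without it has a measured number rather than a limit.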